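Inverting one ring stereocentre on a weak triazole binder

The source may report more compounds than this note shows. Statements on the series, on what has been measured and on what is new or still open speak of the compounds shown alone.

Measured so far:
compound 1 `Fc1cccc(-c2cn([C@@H]3CN4CCC3CC4)nn2)c1`, 2.25 nM
compound 2 `Fc1ccc(COc2cccc(-c3cn([C@@H]4CN5CCC4CC5)nn3)c2)cc1`, 7.17 nM
compound 3 `FCCCOc1cccc(-c2cn([C@H]3CN4CCC3CC4)nn2)c1`, 1630 nM

In an assay on HEK293 cells for displacement of a labelled ligand from Neuronal acetylcholine receptor; alpha3/beta4 (Homo sapiens), read by scintillation counting, with a stated time of 120 min (a lower number here means a stronger inhibitor, a higher number a weaker inhibitor), compound 3 gives the highest number of the three; compound 2 sits far lower at 7.17 nM and compound 1 lower still at 2.25 nM. Compound 4 `FCCCOc1cccc(-c2cn([C@@H]3CN4CCC3CC4)nn2)c1` differs from compound 3 only in the two compounds have the same atoms and bonds; at least one stereo element is drawn with a configuration in one of them and without one in the other: 1 of 3 stereo elements differ; a stereocentre at a saturated ring carbon is drawn R in compound 3 and S in compound 4. For the measured compounds named here, no measured step changes this centre, so no step bears directly on it; the only measured step, a 3.2-fold higher number from compound 1 to compound 2 (0.50 log units; beyond the scatter), alters a different part. In the drawn structures compounds 1 and 2 carry this centre as compound 4 does, and both bind far more strongly than compound 3. Compound 4 is therefore expected to give a much lower number, with an estimated step of a 270-fold lower number from compound 3 to compound 4 (2.43 log units; beyond the scatter). The estimate for compound 4 is 6 nM, within 1.5 nM to 25 nM.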

Compound 4, inhibition constant: 19.5 nM
Compound 4: the middle estimate sits 3.3-fold (0.51 log units) below what was measured; measured number inside the range.
By their numbers in this assay, from the lowest: compound 1; then compound 2; then compound 4; then compound 3.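

Compounds 3 and 4 isolate the stereocentre at the saturated ring carbon, since nothing else changes: moving from R to S gives an 84-fold lower number from compound 3 to compound 4 (1.92 log units; beyond the scatter). With the S centre in place, changes to the side group give much smaller steps: a 2.7-fold higher number from compound 2 to compound 4 (0.43 log units; beyond the scatter) for 2-fluoroethyl in place of 4-fluorophenyl, and an 8.7-fold higher number from compound 1 to compound 4 (0.94 log units; beyond the scatter) for 3-fluoropropoxy in place of fluoro. As far as these compounds go, whether the R centre costs as much with fluoro or (4-fluorobenzyl)oxy on the aromatic carbon stays open. So does how an amine or a carboxylic acid at the end of the chain would compare.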